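Swapping a Cyclic Amide for an Open-Chain One

The source may report more compounds than this note shows. Statements on the series, on what has been measured and on what is new or still open speak of the compounds shown alone.

Compound 1 `COc1ccc2c(c1)OC(c1cc(OC)c(OC)c(OC)c1)C(CO)=C2` gives > 50000 nM in a functional assay for inhibition of nuclear factor NF-kappa-B complex (Homo sapiens) (on this read-out higher numbers stand for weaker inhibition and lower numbers for stronger inhibition), which is a limit of the assay, not a number.
Compound 2 `COc1ccc2c(c1)OC(c1cc(OC)c(OC)c(OC)c1)C(C(=O)N1CCCCC1)=C2` gives > 50000 nM in this assay, again a limit of the assay.
Compound 3 `COC(=O)C1=Cc2ccc(OC)cc2OC1c1cc(OC)c(OC)c(OC)c1` gives 13800 nM in this assay.

Compound 2 thus stands at the limit, as stated by the limit of > 50000 nM in this assay, at which 2 of the 3 values shown sit. Compound 4 `CCCCNC(=O)C1=Cc2ccc(OC)cc2OC1c1cc(OC)c(OC)c(OC)c1` differs from it by butylamino in place of piperidin-1-yl on a carbonyl carbon. Within the data shown here, the one readable step at this carbonyl carbon, an at least 3.6-fold lower number from compound 2 to compound 3 (0.55 log units; beyond the scatter), went to methoxy, not to another amine, while a step that the two limits leave unreadable from compound 1 to compound 2 is unreadable. Among the measured compounds shown here, with no measured step matching this change, compound 4 is expected to stay close to compound 2, a step of about an at least 1.2-fold lower number from compound 2 to compound 4 (0.09 log units; that floor lies within the scatter) in this assay. Compound 4 is therefore estimated at 40000 nM, between 10000 nM and 100000 nM, quite possibly again only a limit.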

Compound 4, half-maximal inhibitory concentration: 25500 nM
Estimate against measurement, compound 4: 1.6-fold (0.20 log units) above; the measured number falls inside the stated range.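

Among the compounds shown, compound 4 is the only amide at this carbonyl carbon with a measured number in this assay, not a limit: butylamino in place of piperidin-1-yl gives an at least 1.9-fold lower number from compound 2 to compound 4 (0.29 log units; that floor lies within the scatter), and butylcarbamoyl in place of hydroxymethyl gives an at least 1.9-fold lower number from compound 1 to compound 4 (0.29 log units; that floor lies within the scatter). Both steps start from a limit of the assay, so each is only a floor: the limit of > 50000 nM in this assay, at which 2 of the 4 values shown sit. Butylamino in place of methoxy gives a 1.8-fold higher number from compound 3 to compound 4 (0.27 log units; within the scatter), so butylcarbamoyl and methoxycarbonyl cannot be told apart here.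

As far as these compounds go, whether a longer chain such as octylamino, or a carboxylic acid at this carbon, would give a lower number stays open. From the compounds shown here alone, the actual number behind the limit of compound 2 also stays open.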